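Replacing Furan with Chlorophenyl on a Bicyclic Acetal Core

The compounds below may be only part of what the source reports. "The series", "measured", "known", "first", "only" and "open" are said of these compounds alone.

Compound 2, `CO[C@@H]1[C@@H](OC)[C@H](c2ccccc2)O[C@@H]2CO[C@@H](c3ccco3)O[C@@H]12`, carries two methoxy groups and a furan-2-yl group on its shared core. In a functional assay on HEL cells (Homo sapiens) for cytotoxicity (a lower number here means that less compound is tolerated, a higher number that more compound is tolerated), compound 2 has no number; its entry reads "not determined" (no result reported). The same holds for compound 3, `CO[C@@H]1[C@@H](OC)[C@H](c2ccccc2)O[C@@H]2CO[C@@H](c3ccc(C)cc3)O[C@@H]12`, which differs only in the aromatic group at that position; in this assay compound 3 likewise has the entry "not determined" (no result reported). For the measured compounds named here, the only measured member of this set is compound 1, `O[C@@H]1[C@@H](O)[C@H](c2ccccc2)O[C@@H]2CO[C@@H](c3ccc(C(F)(F)F)cc3)O[C@@H]12`, which carries two hydroxy groups instead of the methoxy groups and a trifluoromethyl-substituted ring; in this assay compound 1 gives 400 ug/mL.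

Compound 4, `CO[C@@H]1[C@@H](OC)[C@H](c2ccccc2)O[C@@H]2CO[C@@H](c3ccc(Cl)cc3)O[C@@H]12`, arises from compound 2 by the change (4-chlorophenyl in place of furan-2-yl on a saturated ring carbon). Going by the values given here, no step between measured compounds is available to anchor this change, so the expectation is that it moves the minimum cytotoxic concentration by no more than the usual scatter, in no particular direction. Resting on compound 1 as the closest measured relative, compound 4 is expected to give about 300 ug/mL in this assay, within a range from 100 ug/mL to 600 ug/mL.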

Compound 4, minimum cytotoxic concentration: >= 100 ug/mL
Compound 4 was reported as a limit (the forecaster's own chance of this, stated with the estimate: 30%); the middle value lies beyond the limit too.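

No step can be read from compound 2 to compound 4: compound 2 has no number. In this assay compound 4 gives >= 100 ug/mL, which is a limit and not a number. The compounds shown leave open how furan-2-yl and 4-chlorophenyl compare on the shared core.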